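This account rests on a few compounds, and the source may have more. Where it says the series, first, only, none or still open, it means among the compounds named here.

In a functional assay on A549 cells (Homo sapiens) for cytotoxicity, read by MTT assay, with a stated time of 72 h (on this read-out lower numbers stand for stronger inhibition and higher numbers for weaker inhibition), compound 1 `Cc1ccc(S(=O)(=O)c2nc3ccccc3nc2N2CCc3ccccc3C2)cc1` gives > 50000 nM, a limit of the assay and not a number. Compound 2 `COc1ccc(S(=O)(=O)c2nc3ccccc3nc2N2CCc3ccccc3C2)cc1` gives > 50000 nM, also a limit. Compound 3 `O=S(=O)(c1ccc(Br)cc1)c1nc2ccccc2nc1N1CCc2ccccc2C1` gives > 50000 nM, again a limit. Compound 2 thus stands with the others at the limit of > 50000 nM in this assay, at which 3 of the 3 values shown sit.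

Compound 4 `COc1ccc(S(=O)(=O)c2nc3ccccc3nc2N2CCC(O)CC2)cc1` carries 4-hydroxypiperidin-1-yl in place of 1,2,3,4-tetrahydroisoquinolin-2-yl on an aromatic carbon.

The measured steps swap only methyl, methoxy and bromo, and their sizes cannot be read: a step that the two limits leave unreadable from compound 1 to compound 2, a step that the two limits leave unreadable from compound 1 to compound 3 and a step that the two limits leave unreadable from compound 2 to compound 3. None of them touches the group that changes here. With compound 2 at > 50000 nM, no change beyond the scatter is expected in this assay.

The expected result is a number no higher from compound 2 to compound 4 (the limit leaves the size open).

For compound 4 the estimate is 50000 nM, with an expected range from 20000 nM to 100000 nM.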

Compound 4, half-maximal inhibitory concentration: 5110 nM
The estimate for compound 4 lay 9.8-fold (0.99 log units) above the measured number, and the stated range ends above it.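

Putting 4-hydroxypiperidin-1-yl in place of 1,2,3,4-tetrahydroisoquinolin-2-yl gives an at least 9.7-fold lower number from compound 2 to compound 4 (0.99 log units; beyond the scatter) in this assay, so this position can change the read-out, whereas the steps among methyl, methoxy and bromo cannot be read. Going by these compounds, the size stays open because the value for compound 2 is a limit. Compound 4 is the only compound shown with a measured number rather than a limit: the limit of > 50000 nM in this assay, at which 3 of the 4 values shown sit.

On these data alone, it remains open whether the hydroxy group or the loss of the fused aromatic ring carries this step. Also open, as far as these compounds go, is how an amine or a carboxylic acid would compare in place of that hydroxy group.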